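From phenyl to bromo: what one swap may cost

This account rests on a few compounds, and the source may have more. Where it says the series, first, only, none or still open, it means among the compounds named here.

Values measured in a functional assay on KG-1 cells (Homo sapiens) for cytotoxicity, read by luminescence and CellTiter-Glo, with a stated time of 3 days (a higher number here means a weaker inhibitor, a lower number a stronger inhibitor), follow
Compound 1 `N#Cc1ccc(NC(=O)c2ccc(Br)cc2O)c(Cl)c1` gives 790 nM
Compound 2 `N#Cc1ccc(NC(=O)c2ccc(-c3cccnc3)cc2O)cc1` gives 7940 nM
Compound 3 `N#Cc1ccc(NC(=O)c2ccc(-c3ccccc3)cc2O)cc1` gives 410 nM

Compound 3 at 410 nM lies within the usual scatter of compound 1 at 790 nM and well apart from compound 2 at 7940 nM in this small set. Compound 4 `N#Cc1ccc(NC(=O)c2ccc(Br)cc2O)cc1` puts bromo in place of the phenyl of compound 3 bromo in place of phenyl on an aromatic carbon on that same aromatic carbon. Among the measured compounds shown here, one measured step touches this place, namely a 19-fold lower number from compound 2 to compound 3 (1.29 log units; beyond the scatter) and it shows that the group here can matter greatly. That step swapped one ring for another, so it gives no direct measure of a swap to bromo. Compound 1 at 790 nM carries bromo but also a chloro group absent from compound 4, and the effect of that chloro group has not been measured. The expected change is a 3.7-fold higher number from compound 3 to compound 4 (0.56 log units; beyond the scatter) in this assay and so a moderately higher number. For compound 4 the estimated value is 1500 nM with an expected range from 450 nM to 5000 nM.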

Compound 4, half-maximal inhibitory concentration: 1450 nM
Compound 4: middle estimate off by 1.0-fold (0.01 log units), on the high side, within the range that was stated.
By their numbers in this assay, from the lowest: compounds 3, 1 and 4 (each within the scatter of the next, the first and the last beyond it); then compound 2.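

In this assay, bromo in place of phenyl gives a 3.5-fold higher number from compound 3 to compound 4 (0.55 log units; beyond the scatter), while bromo in place of pyridin-3-yl gives a 5.5-fold lower number from compound 2 to compound 4 (0.74 log units; beyond the scatter). Bromo, which has no ring, therefore lands between the two rings, so the number at this carbon does not depend on a ring being present. Hydrogen in place of chloro gives a 1.8-fold higher number from compound 1 to compound 4 (0.26 log units; within the scatter), so that swap cannot be told from the scatter. Nothing available explains these steps. On these data alone, how an amine or a carboxylic acid on this carbon would compare remains open.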